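The compounds below may be only part of what the source reports. "The series", "measured", "known", "first", "only" and "open" are said of these compounds alone.

Working notes on the series. Compound 1 `Nc1sc(-c2ccc(Cl)cc2)c(-c2ccc(Cl)cc2)c1C(=O)N1CCCCC1`, compound 2 `Nc1sc(-c2ccc(Cl)cc2)c(-c2ccc(Cl)cc2)c1C(=O)N1CCCCC1=O` and compound 3 `Nc1sc(-c2ccc(Cl)cc2)c(-c2ccc(Cl)cc2)c1C(=O)NC1CCC(O)CC1` share one core; compound 4 `Nc1sc(-c2ccc(Cl)cc2)c(-c2ccc(Cl)cc2)c1C(=O)NCc1ccccc1` is not yet measured. In a functional assay on A549 cells (Homo sapiens) for inhibition, read by sulforhodamine B assay, with a stated time of 72 h (a lower number here means a stronger inhibitor, a higher number a weaker inhibitor), compound 1 gives 4620 nM, compound 2 gives 1820 nM and compound 3 gives 250 nM. Compound 2 thus stands second highest of the three, with a 2.5-fold lower number from compound 1 to compound 2 (0.40 log units; beyond the scatter) and a 7.3-fold lower number from compound 2 to compound 3 (0.86 log units; beyond the scatter). Compound 4 carries benzylamino in place of 2-oxopiperidin-1-yl on a carbonyl carbon. Both steps that bear on this replace a nitrogen lacking a hydrogen-bond donor with one that has one: a 7.3-fold lower number from compound 2 to compound 3 (0.86 log units; beyond the scatter) and an 18-fold lower number from compound 1 to compound 3 (1.27 log units; beyond the scatter). A lower number in this assay is therefore expected for compound 4, though benzylamino differs from the (4-hydroxycyclohexyl)amino of compound 3, so a smaller step than a 7.3-fold lower number from compound 2 to compound 3 (0.86 log units; beyond the scatter) is expected. The estimate for compound 4 is 600 nM, range 180 nM to 2000 nM. This corresponds to an expected 3.0-fold lower number from compound 2 to compound 4 (0.48 log units; beyond the scatter).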

Compound 4, half-maximal inhibitory concentration: 16300 nM
Beside the measured number, compound 4's estimate is 27-fold (1.43 log units) below it; the measured number lies above the stated range.
By their numbers in this assay, from the lowest: compound 3; then compound 2; then compound 1; then compound 4.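

At this carbonyl carbon, the amide hydrogen alone does not bring a lower number in this assay: benzylamino carries that hydrogen, yet the change gives a 9.0-fold higher number from compound 2 to compound 4 (0.95 log units; beyond the scatter) and a 3.5-fold higher number from compound 1 to compound 4 (0.55 log units; beyond the scatter). What the nitrogen carries matters strongly, with a 65-fold higher number from compound 3 to compound 4 (1.81 log units; beyond the scatter) when benzyl replaces 4-hydroxycyclohexyl. No measured data here explain this gap. From the compounds shown here alone, whether the gain in compound 3 depends on its hydroxyl or on its cyclohexyl ring stays open. A plain cyclohexylamino group at this carbonyl carbon would separate the two.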